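Methyl on the amine ring of compound 1

This account rests on a few compounds, and the source may have more. Where it says the series, first, only, none or still open, it means among the compounds named here.

Measured compounds and their values:
compound 1, `CC1=C(c2cccc(O)c2)C(c2ccc(OC[C@@H](C)N3CCCC3)cc2)Oc2ccc(O)cc21`, 0.2 nM;
compound 2, `CC1=C(c2ccc(C#N)cc2)C(c2ccc(OC[C@H](C)N3CC[C@@H](C)C3)cc2)Oc2ccc(O)cc21`, 10 nM;
compound 3, `CC1=C(c2cccc(O)c2)C(c2ccc(OC[C@H](C)N3CC[C@@H](C)C3)cc2)Oc2cc(O)ccc21`, 0.3 nM.

In a functional assay on MCF7 cells (Homo sapiens) for antiproliferative activity, read by CellTiter-Glo, with a stated time of 5 days (on this read-out higher numbers stand for weaker inhibition and lower numbers for stronger inhibition), compound 1 gives the lowest of the three numbers. Compound 3, with its own amine ring and its hydroxyl placed differently on the shared core, gives a number that sits within the usual scatter of compound 1, so no order between the two can be stated. Compound 2, which carries a nitrile in place of the phenol, gives a markedly higher number, beyond the scatter.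

The next compound, compound 4, `CC1=C(c2cccc(O)c2)C(c2ccc(OC[C@H](C)N3CC[C@H](C)C3)cc2)Oc2ccc(O)cc21`, differs from compound 1 in one place: a group of 8 heavy atoms (7 carbon, 1 nitrogen; one five-membered non-aromatic ring with 1 hetero atom) in place of a group of 7 heavy atoms (6 carbon, 1 nitrogen; one five-membered non-aromatic ring with 1 hetero atom), on a saturated chain carbon bound to an oxygen on an aromatic ring. The same kind of amine ring with a methyl is already present in compound 3, which differs from compound 1 in the position of a core hydroxyl as well and still gives a value within the scatter of compound 1. Among the measured compounds shown here, no single-point step between measured compounds is available for this change.

The expected step in this assay from compound 1 to compound 4 is therefore a 1.5-fold higher number from compound 1 to compound 4 (0.18 log units; within the scatter), a change not expected to exceed the scatter. For compound 4 the estimate is 0.3 nM, with a range from 0.1 nM to 1 nM.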

Compound 4, half-maximal inhibitory concentration: 0.2 nM
For compound 4 the middle estimate is 1.5-fold (0.18 log units) above the measured one, within the range that was stated.
By their numbers in this assay, from the lowest: compounds 1, 4 and 3 (each within the scatter of the next); then compound 2.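

In this assay, among the compounds shown here, the exchange of the group on the saturated chain carbon bound to an oxygen on an aromatic ring reads no change at the digits printed from compound 1 to compound 4 (within the scatter), the first comparison that isolates this group, since none of the earlier compounds formed a pair differing in one place. At this position, the larger group with 8 heavy atoms and 2 defined stereocentres therefore gives a number indistinguishable from that of the group with 7 heavy atoms and 1 defined stereocentre, with the phenol and the rest of the shared core held constant. No supporting measurement bears on this result, so the data give no explanation for it.

For the compounds shown here, the single step cannot separate the added methyl from the stereocentres that come with the exchanged group, so the contribution of each remains unresolved. Also open, on these data alone, is whether a larger amine at this position, such as a piperidine ring or a ring bearing an ethyl in place of the methyl, would stay within the scatter of compound 1 or give a clearly higher number.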